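Trifluoromethyl aniline swap on the methoxy-bearing core

This account rests on a few compounds, and the source may have more. Where it says the series, first, only, none or still open, it means among the compounds named here.

Measured in a functional assay on MCF7 cells (Homo sapiens) for antiproliferative activity, read by MTT assay, with a stated time of 48 h; on this read-out lower numbers stand for stronger inhibition and higher numbers for weaker inhibition:
- compound 1 `COc1ccc(-c2c(Nc3cccc(C(F)(F)F)c3)c3ccccc3oc2=O)cc1` gives 21600 nM
- compound 2 `COc1ccc(-c2c(Nc3ccc(C)cc3)c3ccc(OC)cc3oc2=O)cc1` gives 66900 nM

Of these two numbers, the higher belongs to compound 2, and its gap to compound 1 lies beyond the scatter. Compound 3 `COc1ccc(-c2c(Nc3cccc(C(F)(F)F)c3)c3ccc(OC)cc3oc2=O)cc1` is the next case, and its change from compound 2 is 3-(trifluoromethyl)phenyl in place of 4-methylphenyl on a nitrogen on an aromatic ring. Going by the values given here, no measured pair isolates this change. Compound 1 carries the same 3-(trifluoromethyl)phenyl on a different core and stands at 21600 nM, so a modest step to a lower number is expected in this assay, near the edge of the scatter. The estimated step is a 2.2-fold lower number from compound 2 to compound 3 (0.35 log units; beyond the scatter). For compound 3 the expected value is 30000 nM, within an estimated range of 12000 nM to 70000 nM.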

Compound 3, half-maximal inhibitory concentration: 36200 nM
Compound 3: the middle estimate sits 1.2-fold (0.08 log units) below what was measured; the measured number falls inside the stated range.
By their numbers in this assay, from the lowest: compounds 1, 3 and 2 (each within the scatter of the next, the first and the last beyond it).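

In this assay, 3-(trifluoromethyl)phenyl in place of 4-methylphenyl on a nitrogen on an aromatic ring gives a 1.8-fold lower number from compound 2 to compound 3 (0.27 log units; within the scatter), so this swap does not clearly separate the two groups on the shared core. The other single change, methoxy in place of hydrogen on an aromatic carbon, gives a 1.7-fold higher number from compound 1 to compound 3 (0.22 log units; within the scatter), so with 3-(trifluoromethyl)phenyl held fixed, this position also shows no clear effect. Nothing available accounts for either step.

From the compounds shown here alone, whether 4-methylphenyl gives a similar number on the core of compound 1 remains open, so the two changes cannot yet be tested for independence. Going by these compounds, it is also open whether an amine or a carboxylic acid on the phenyl ring attached to the nitrogen, or a longer chain in place of methoxy, would produce a step beyond the scatter.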